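Chain variation on the aromatic nitrogen: outlook for compound 3

The source may report more compounds than this note shows. Statements on the series, on what has been measured and on what is new or still open speak of the compounds shown alone.

Measured so far:
- In an assay on isolated protein (Oryctolagus cuniculus) with Thromboxane-A synthase (Homo sapiens) as the target, tested at 1 uM (on this read-out higher numbers stand for more inhibition at the one concentration tested (going by the name of the read-out) and lower numbers for less inhibition), compound 1 `C=CCn1nc(-c2cccnc2)c2ccccc2c1=O` gives 70%.
- In this assay compound 2 `O=c1c2ccccc2c(-c2cccnc2)nn1CCSc1ncccn1` gives 86%.

Going by the values given here, compound 2 stands highest of the two numbers; its nearest neighbour is compound 1, and the one measured step, a number 16 percentage points higher from compound 1 to compound 2 (beyond the scatter), lies beyond the scatter. Among the compounds with values here, that step is the only comparison in hand, and it concerns the chain on the aromatic nitrogen.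

Compound 3 `O=C(O)CCCn1nc(-c2cccnc2)c2ccccc2c1=O` is not yet measured. It differs from compound 2 as follows: carboxymethyl in place of (pyrimidin-2-yl)sulfanyl on a saturated chain carbon, two bonds along the chain from an aromatic nitrogen. Within the data shown here, no measured pair shows a carboxymethyl entering or a (pyrimidin-2-yl)sulfanyl leaving, so the step from compound 1 to compound 2 bears only indirectly: it shows that a change at this chain position can move the read-out by a modest amount, and that the group now leaving accompanied the higher number. A modest drop in this assay is therefore expected, but with wide uncertainty. For compound 3 the expected step is a number 11 percentage points lower from compound 2 to compound 3 (beyond the scatter). Compound 3 is estimated at 75%, within 50% to 92%.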

Compound 3, a percentage reported as inhibition, at one concentration (the size of the read-out at that concentration, not a potency): 73%
Compound 3: the middle estimate sits 2 percentage points above what was measured; the measured number falls inside the stated range.
By their numbers in this assay, from the lowest: compounds 1 and 3 (each within the scatter of the next); then compound 2.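

In this assay, carboxymethyl in place of (pyrimidin-2-yl)sulfanyl on a saturated chain carbon, two bonds along the chain from an aromatic nitrogen, gives a number 13 percentage points lower from compound 2 to compound 3 (beyond the scatter) and so ties the higher number of compound 2 to that particular chain end, not to any substitution at this place. The change of vinyl to 2-carboxyethyl on a saturated chain carbon bound to an aromatic nitrogen gives a number 3 percentage points higher from compound 1 to compound 3 (within the scatter) and shows that a chain can be altered here without a step beyond the scatter, so the position is not sensitive to every change. No measurement among the data accounts for either step.

The compounds shown leave open whether the sulfur or the pyrimidine ring goes with the higher number, a question that a phenylsulfanyl or a pyrimidin-2-yl end without sulfur would address on the same chain. From the compounds shown here alone, it also remains open how a longer chain ending in a carboxylic acid, or a chain ending in an amine, would read at this one concentration.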